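The source may hold more compounds than are shown below. What is called first, only, known or untested is meant among the compounds shown, and "the series" means these compounds.

Three compounds built on one shared core, each carrying a saturated chain ester, were tested for their effect on lung-derived cancer cells. Compound 1 `CCCCCCCCCCOC(=O)CCC(=O)N1CCN(CCCOc2cc3c(Nc4ccc(F)c(Cl)c4)ncnc3cc2OC)CC1` was examined in a functional assay on A549 cells (Homo sapiens) for cytotoxicity, read by MTT assay, with a stated time of 24 h, tested at 20 uM (on this read-out lower numbers stand for a stronger effect and higher numbers for a weaker effect at the one concentration tested), and gave 88.2%. Compound 2 `CCCCCCCCCCCOC(=O)CCC(=O)N1CCN(CCCOc2cc3c(Nc4ccc(F)c(Cl)c4)ncnc3cc2OC)CC1` differs from compound 1 by methyl in place of hydrogen on a saturated chain carbon, ten or more bonds along the chain from an oxygen next to a carbonyl group, and in this assay compound 2 gave 85.2%. The step of a number 3 percentage points lower from compound 1 to compound 2 (within the scatter) is therefore small. Compound 3 `CCCCCCCCCCCCCCOC(=O)CCC(=O)N1CCN(CCCOc2cc3c(Nc4ccc(F)c(Cl)c4)ncnc3cc2OC)CC1` differs from compound 1 by butyl in place of hydrogen on a saturated chain carbon, ten or more bonds along the chain from an oxygen next to a carbonyl group; in this assay compound 3 gave 92.3%. The steps of a number 4.1 percentage points higher from compound 1 to compound 3 (within the scatter) and a number 7.1 percentage points higher from compound 2 to compound 3 (within the scatter) are likewise small, so all three compounds sit close together on this read-out.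

Compound 4 `CCCCCCCCCCCCCCCOC(=O)CCC(=O)N1CCN(CCCOc2cc3c(Nc4ccc(F)c(Cl)c4)ncnc3cc2OC)CC1` has not yet been measured. It differs from compound 3 by methyl in place of hydrogen on a saturated chain carbon, ten or more bonds along the chain from an oxygen next to a carbonyl group, which is the same change as that between compound 1 and compound 2. Because that earlier change produced only a number 3 percentage points lower from compound 1 to compound 2 (within the scatter), the expected step here is a number 2.3 percentage points lower from compound 3 to compound 4 (within the scatter), a small one. On that basis compound 4 is expected to give about 90% in this assay, with a range estimated from 81% to 99%.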

Compound 4, a percentage reported as activity, at one concentration (the size of the read-out at that concentration, not a potency): 91.2%
Beside the measured number, compound 4's estimate is 1.2 percentage points below it; low and high end bracket the measured number.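

In this assay, methyl in place of hydrogen on the saturated chain carbon gives a number 1.1 percentage points lower from compound 3 to compound 4 (within the scatter), and this agrees with the earlier step for the same change: the same change on two cores in this assay, a number 3 percentage points lower (within the scatter) from compound 1 to compound 2 and a number 1.1 percentage points lower (within the scatter) from compound 3 to compound 4, 1.9 percentage points apart, within the scatter of two such steps. The butyl change, with a number 6 percentage points higher from compound 2 to compound 4 (within the scatter), reads the same way when set against its earlier step: the same change on two cores in this assay, a number 4.1 percentage points higher (within the scatter) from compound 1 to compound 3 and a number 6 percentage points higher (within the scatter) from compound 2 to compound 4, 1.9 percentage points apart, within the scatter of two such steps. The pentyl change, with a number 3 percentage points higher from compound 1 to compound 4 (within the scatter), is also small, so these chain changes carry from one core to another only in the sense that each stays within the scatter; this does not show that a change with a clear effect on this read-out would carry over in the same way.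

The compounds shown leave open whether a much shorter chain, such as an ethyl ester, would separate from these four on this read-out. They also leave open what a carboxylic acid or an amine at the end of the chain would do.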